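Hydroxy placement on the ring of compound 1

The compounds below may be only part of what the source reports. "The series", "measured", "known", "first", "only" and "open" are said of these compounds alone.

Values in an ADME assay on PC-12 cells (Rattus norvegicus) for cytotoxicity, read by WST assay, with a stated time of 24 h; on this read-out lower numbers stand for higher toxicity in this test and higher numbers for lower toxicity in this test:
- compound 1 `O=C(/C=C/c1ccc(O)c(O)c1)CC(=O)/C=C/c1cccc(O)c1O`: 16000 nM
- compound 2 `O=C(/C=C/c1cccc(O)c1)CC(=O)/C=C/c1cccc(O)c1O`: 38000 nM
- compound 3 `O=C(/C=C/c1ccc(O)cc1)CC(=O)/C=C/c1cccc(O)c1O`: 8500 nM

Compound 1 takes the middle place among these three numbers, but its nearest neighbour cannot be separated from it: a 1.9-fold lower number from compound 1 to compound 3 (0.27 log units; within the scatter). Its furthest neighbour is clearer: a 2.4-fold higher number from compound 1 to compound 2 (0.38 log units; beyond the scatter).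

The next compound to be read is compound 4 `O=C(/C=C/c1cc(O)ccc1O)CC(=O)/C=C/c1cccc(O)c1O`, which keeps the shared core and has the same atoms as compound 1, joined differently: 2,5-dihydroxyphenyl in place of 3,4-dihydroxyphenyl on a double-bonded chain carbon bound to a double-bonded chain carbon. In words, 2,5-dihydroxyphenyl stands in place of 3,4-dihydroxyphenyl on a double-bonded chain carbon bound to a double-bonded chain carbon.

The two steps above each put hydrogen in place of hydroxy on the group that changes here, and neither is large. Among the measured compounds shown here, the step nearest in kind is the one that swaps 3-hydroxyphenyl for 4-hydroxyphenyl: a 4.5-fold lower number from compound 2 to compound 3 (0.65 log units; beyond the scatter). It is modest, and it shows that hydroxy placement alone can move the number beyond the scatter. For the measured compounds named here, no measured compound carries 2,5-dihydroxyphenyl, so the data set no firm direction. A step within the scatter is the likeliest outcome, and a modest step either way remains possible.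

The estimated step is a 1.1-fold lower number from compound 1 to compound 4 (0.06 log units; within the scatter).

For compound 4 the expected value is 14000 nM, with an estimated range from 5500 nM to 35000 nM.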

Compound 4, half-maximal cytotoxic concentration: 53000 nM
Compound 4: the middle estimate sits 3.8-fold (0.58 log units) below what was measured; the measured number lies above the stated range.
By their numbers in this assay, from the lowest: compounds 3 and 1 (each within the scatter of the next); then compounds 2 and 4 (each within the scatter of the next).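

In this assay, rearranging the hydroxy groups alone moves the number beyond the scatter, since 2,5-dihydroxyphenyl and 3,4-dihydroxyphenyl match in every count printed for them: a 3.3-fold higher number from compound 1 to compound 4 (0.52 log units; beyond the scatter). Compound 4 also stands clearly apart from the monohydroxy compound 3, a 6.2-fold higher number from compound 3 to compound 4 (0.79 log units; beyond the scatter), but cannot be separated from the monohydroxy compound 2, a 1.4-fold higher number from compound 2 to compound 4 (0.14 log units; within the scatter), so at this position the number does not follow the count of hydroxy groups. Hydrogen in place of hydroxy on an aromatic carbon gives steps within the scatter on two cores, with a 2.4-fold higher number from compound 1 to compound 2 (0.38 log units; beyond the scatter) going against this as a step of the same kind beyond the scatter: the same change on two cores in this assay, a 1.9-fold lower number (0.27 log units; within the scatter) from compound 1 to compound 3 and a 1.4-fold lower number (0.14 log units; within the scatter) from compound 4 to compound 2, 1.3-fold (0.13 log units) apart, within the scatter of two such steps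

The compounds shown leave open whether the number at this position depends on hydroxy itself, as a methoxy or an amine on the same ring carbons would test. They also leave open whether the gap between 2,5-dihydroxyphenyl and 3,4-dihydroxyphenyl holds when the 2,3-dihydroxyphenyl group at the other end of the shared core is replaced.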